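This account rests on a few compounds, and the source may have more. Where it says the series, first, only, none or still open, it means among the compounds named here.

Compound 1 `CN(C)C(=O)CN1CCC(c2cc3c(-c4ccc(=O)n(C5CCC5)c4)ccnc3[nH]2)CC1` is the starting point of this account. In an ADME assay on microsomes from liver (Homo sapiens) for metabolic stability (on this read-out higher numbers stand for fast clearance and lower numbers for slow clearance), compound 1 gives < 3 uL/min, which is a limit of the assay rather than a number. Compound 1 therefore sits at the limit of < 3 uL/min in this assay, at which 1 of the 3 values shown sits. Two other compounds of the same series have numbers. Compound 2 `CC(C)n1nc(-c2ccnc3[nH]c(C4CCN(CC(=O)N(C)C)CC4)cc23)ccc1=O` gives 13 uL/min in this assay. Compound 3 `CC(C)n1cc(-c2ccnc3[nH]c(C4CCN(CC(=O)N5CCCC5)CC4)cc23)ccc1=O` gives 45 uL/min in this assay. Among the measured compounds shown here, no two of these three compounds differ in a single place, so no measured step connects them, and the two numbers of compound 2 and compound 3 show only where each of them stands.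

Compound 4 `CN(C)C(=O)CN1CCC(c2cc3c(-c4ccc(=O)n(CC5CCOCC5)c4)ccnc3[nH]2)CC1` has not yet been measured in this assay. It differs from compound 1 in one place: (oxan-4-yl)methyl in place of cyclobutyl on an aromatic nitrogen. The amide and the shared core of compound 1 are kept unchanged.

Because compound 1 stands at < 3 uL/min, any observable move for compound 4 in this assay can only be upward. The account expects a modest step of an at least 1.6-fold higher number from compound 1 to compound 4 (0.22 log units; that floor lies within the scatter), not clearly beyond the scatter of repeated measurements. For compound 4 the expected value in this assay is estimated at 5 uL/min, within a range from 2.5 uL/min to 14 uL/min.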

Compound 4, intrinsic clearance in a liver preparation (reported as CLH), per the amount of preparation that the assay uses: 20 uL/min
Compound 4: middle estimate off by 4.0-fold (0.60 log units), on the low side; the whole stated range lies below it.
By their numbers in this assay, from the lowest: compounds 2 and 4 (each within the scatter of the next); then compound 3. At a limit, below all of these: compound 1.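

In this assay, putting (oxan-4-yl)methyl in place of cyclobutyl on an aromatic nitrogen gives an at least 6.6-fold higher number from compound 1 to compound 4 (0.82 log units; beyond the scatter), with the amide and the shared core kept unchanged. Among the compounds shown here, the earlier compounds offered no step in a single place, so this is the first measured sign that the group on this nitrogen bears on clearance, and the step lies beyond the scatter. Compound 1 gives < 3 uL/min, which is a limit of the assay and not a number, so the step fixes only a floor for the size of this change.

The compounds shown leave open whether the step follows from the ring oxygen with its hydrogen-bond acceptor or from the larger group as a whole, and a cyclohexylmethyl group on the same nitrogen, with carbon in place of that oxygen, would separate the two. How far the step truly reaches also stays open, because the starting value of this comparison is not a number: the limit of < 3 uL/min in this assay, at which 1 of the 4 values shown sits.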